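Chlorine in Place of Hydrogen on the Shared Core

The compounds below may be only part of what the source reports. "The series", "measured", "known", "first", "only" and "open" are said of these compounds alone.

Compound 1 `ClCc1ccccc1Cn1cnc2c(Cl)nc(Cl)nc21` and compound 2 `ClCc1ccccc1Cn1cnc2c(Cl)ncnc21` differ in one place: chloro in place of hydrogen on an aromatic carbon. In a functional assay on UACC-62 cells (Homo sapiens) for cytotoxicity, read by sulforhodamine B assay, with a stated time of 48 h (a higher number here means a weaker inhibitor of growth, a lower number a stronger inhibitor of growth), compound 2 gives 3310 nM and compound 1 gives 1310 nM, a step of a 2.5-fold lower number from compound 2 to compound 1 (0.40 log units; beyond the scatter). Compound 3 `ClCc1cccc(Cn2cnc3ncnc(Cl)c32)c1` has the same atoms as compound 2 joined differently; the difference between the two cores is not broken down here. In this assay compound 3 gives 2180 nM, a number within the scatter of compound 2 and of compound 1. Compound 4 `ClCc1cccc(Cn2cnc3nc(Cl)nc(Cl)c32)c1` is still to be measured. It differs from compound 3 by chloro in place of hydrogen on an aromatic carbon, the same kind of change as that from compound 2 to compound 1, and the two place descriptions agree word for word. The expected step is a 2.5-fold lower number from compound 3 to compound 4 (0.40 log units; beyond the scatter), which rests on the pair of compound 2 and compound 1 because of a 2.5-fold lower number from compound 2 to compound 1 (0.40 log units; beyond the scatter), a single precedent. For compound 4 the estimated number in this assay is 870 nM, within a range from 400 nM to 2000 nM.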

Compound 4, concentration for 50% growth inhibition: 1020 nM
Compound 4: the middle estimate sits 1.2-fold (0.07 log units) below what was measured; the measured number falls inside the stated range.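

In this assay chloro in place of hydrogen on an aromatic carbon, between two ring nitrogen atoms, gives a 2.1-fold lower number from compound 3 to compound 4 (0.33 log units; beyond the scatter). The change therefore carries over between these two cores, which have the same atoms joined differently, and the size of the step holds within the scatter: the same change on two cores in this assay, a 2.5-fold lower number (0.40 log units; beyond the scatter) from compound 2 to compound 1 and a 2.1-fold lower number (0.33 log units; beyond the scatter) from compound 3 to compound 4, 1.2-fold (0.07 log units) apart, within the scatter of two such steps. Within the data shown here, this rests on only two matched pairs in one cell line with one read-out, so it shows neither that the step would hold on a further core or in another assay nor why chloro gives this step.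

The compounds shown compare only chloro with hydrogen at this aromatic carbon, so it remains open whether an amine, a methoxy group or a longer chain there would give a step of similar size on both cores. Also open, as far as these compounds go, is how the number would move if an amine or a hydroxyl group took the place of the chloro on the chloromethyl group, which all four compounds carry.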